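The source may hold more compounds than are shown below. What is called first, only, known or untested is meant among the compounds shown, and "the series" means these compounds.

Compound 2 `Cc1nc2cc(C(=O)NCc3ccc(F)cc3S(C)(=O)=O)nn2c(-c2cc(F)c3c(c2C)CCCO3)c1[C@H](OC(C)(C)C)C(=O)O` is one of two compounds whose cytotoxicity has been measured in an ADME assay on MT2 cells (Homo sapiens) for cytotoxicity; on this read-out lower numbers stand for higher toxicity in this test and higher numbers for lower toxicity in this test. In this assay compound 2 gives > 40000 nM, which is a limit of the assay and not a number. Compound 1 `CCCc1cc(CNC(=O)c2cc3nc(C)c([C@H](OC(C)(C)C)C(=O)O)c(-c4cc(F)c5c(c4C)CCCO5)n3n2)ccc1F` differs from it in a single group. In this assay compound 1 gives > 20000 nM, again a limit rather than a number. The step that the two limits leave unreadable from compound 1 to compound 2, 4-fluoro-2-(methylsulfonyl)phenyl in place of 4-fluoro-3-propylphenyl on a saturated chain carbon bound to an amide-type nitrogen, has no readable size, since the two values sit at the limit of > 20000 nM in this assay, at which 1 of the 2 values shown sits, and (the limit of > 40000 nM in this assay, at which 1 of the 2 values shown sits). Compound 3 `Cc1nc2cc(C(=O)NCCC(C)C)nn2c(-c2cc(F)c3c(c2C)CCCO3)c1[C@H](OC(C)(C)C)C(=O)O` has not yet been measured. It differs from compound 2 by isobutyl in place of 4-fluoro-2-(methylsulfonyl)phenyl on a saturated chain carbon bound to an amide-type nitrogen. Going by the values given here, the only measured step touches the same position yet yields no size, so no direction beyond the scatter can be drawn from it. Compound 3 is therefore expected to show 40000 nM in this assay, within a range from 20000 nM to 100000 nM. The estimated step of a number no higher from compound 2 to compound 3 (the limit leaves the size open) is expected to stay within the scatter, with a good chance that only a limit is again reported.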

Compound 3, half-maximal cytotoxic concentration: > 40000 nM
Compound 3 ended at the assay's limit; the forecaster's own chance of this, stated with the estimate: 85%; the middle value lies on the limit itself.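

In this assay compound 3 gives > 40000 nM, a limit of the assay and not a number. The steps linking compound 3 to compound 1 and compound 2 cannot be read. The compounds shown leave open whether the group on the saturated chain carbon bound to an amide-type nitrogen affects this read-out at all.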